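The compounds below may be only part of what the source reports. "The series", "measured", "known", "first", "only" and "open" are said of these compounds alone.

Measured so far, all in a functional assay on RL cells (Homo sapiens) for cytotoxicity, with a stated time of 48 h; a higher number here means a weaker inhibitor, a lower number a stronger inhibitor:

compound 1, `COc1cc(OC)c(C(=O)/C=C/c2ccccc2SC)c(OC)c1`, gives 8300 nM
compound 2, `COc1cccc(/C=C/C(=O)c2c(OC)cc(OC)cc2OC)c1`, gives 5900 nM
compound 3, `COc1cc(O)c(C(=O)/C=C/c2ccccc2SC)c(OC)c1`, gives 8900 nM

The three values sit close together. Compound 1 and compound 2 share the same carbonyl-bearing core and differ only at the far end, where (3-methoxyphenyl in place of 2-(methylsulfanyl)phenyl on a double-bonded chain carbon bound to a double-bonded chain carbon); the step is a 1.4-fold lower number from compound 1 to compound 2 (0.15 log units; within the scatter). Compound 3 is compound 1 with hydrogen in place of methyl on an oxygen on an aromatic ring, and that change made a 1.1-fold higher number from compound 1 to compound 3 (0.03 log units; within the scatter).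

Compound 4, `COc1cccc(/C=C/C(=O)c2c(O)cc(OC)cc2OC)c1`, is not yet measured. It is compound 2 with hydrogen in place of methyl on an oxygen on an aromatic ring. For the measured compounds named here, this is the same change as the one from compound 1 to compound 3, made on the same place, only on the core carrying the other aryl group. Going by the values given here, the step expected from this change is a 1.1-fold higher number from compound 2 to compound 4 (0.03 log units; within the scatter), which rests on the single earlier instance, a 1.1-fold higher number from compound 1 to compound 3 (0.03 log units; within the scatter), where it stayed within the scatter. On that basis compound 4 is expected to give 6300 nM in this assay, with a plausible range from 3000 nM to 13000 nM.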

Compound 4, half-maximal inhibitory concentration: 9000 nM
Compound 4: middle estimate off by 1.4-fold (0.15 log units), on the low side; the measured number falls inside the stated range.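

In this assay the change from methoxy to hydroxy gives a 1.5-fold higher number from compound 2 to compound 4 (0.18 log units; within the scatter) and the two instances of it do not differ: the same change on two cores in this assay, a 1.1-fold higher number (0.03 log units; within the scatter) from compound 1 to compound 3 and a 1.5-fold higher number (0.18 log units; within the scatter) from compound 2 to compound 4, 1.4-fold (0.15 log units) apart, within the scatter of two such steps
On both cores, the one bearing 2-(methylsulfanyl)phenyl and the one bearing 3-methoxyphenyl, the change stays within the scatter, so the finding that carries over is a step too small to read. This does not show a real effect of the change in either direction, and two instances say nothing about other cores.

Open, going by these compounds, is whether an amine or a longer alkoxy chain in place of the hydroxy would give a step beyond the scatter. Also open, on these data alone, is whether a carboxylic acid on the far aryl group would do so.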